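The compounds below may be only part of what the source reports. "The series", "measured", "known", "first", "only" and "open" are said of these compounds alone.

Measured in a functional assay on DLD-1 cells (Homo sapiens) for inhibition, read by luminescence, with a stated time of 3 days; a higher number here means a weaker inhibitor of growth, a lower number a stronger inhibitor of growth:

- Compound 1 `CC(=O)N1CCN(C(=O)[C@@H]2CC[C@@H](C)N2C(=O)C2=C(C(C)C)N3C(=N[C@@](C)(c4ccc(Cl)cc4)[C@H]3c3ccc(Cl)cc3)S2)CC1`: 16000 nM
- Compound 2 `CC[C@@H]1CC[C@@H](C(=O)N2CCOCC2)N1C(=O)C1=C(C(C)C)N2C(=N[C@@](C)(c3ccc(Cl)cc3)[C@H]2c2ccc(Cl)cc2)S1`: 4200 nM
- Compound 3 `CC(=O)N1CCN(C(=O)[C@@H]2CC[C@@H](C)N2C(=O)C2=C(C(C)C)N3C(=N[C@@](C)(c4ccc(Cl)cc4)[C@H]3c3ccc(Cl)cc3)S2)C[C@H]1C`: 11000 nM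

Compound 3 lies within the scatter of compound 1, while compound 2 shows a lower number, beyond the scatter.

Compound 4 `CC(C)C1=C(C(=O)N2[C@H](C)CC[C@H]2C(=O)N2CCN(C)C(C)(C)C2)SC2=N[C@@](C)(c3ccc(Cl)cc3)[C@@H](c3ccc(Cl)cc3)N21` has not been measured. It keeps the shared core of compound 3 and differs as follows: a group of 9 heavy atoms (7 carbon, 2 nitrogen; one six-membered non-aromatic ring with 2 hetero atoms) in place of a group of 10 heavy atoms (7 carbon, 2 nitrogen, 1 oxygen; one six-membered non-aromatic ring with 2 hetero atoms), on a carbonyl carbon. Both groups hold one six-membered non-aromatic ring with 2 hetero atoms, but only the group that leaves has a double bond outside aromatic rings and a defined stereocentre.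

Among the compounds with values here, only one measured step bears on this change: a 1.5-fold lower number from compound 1 to compound 3 (0.16 log units; within the scatter). That step altered the same group, but only by a methyl in place of hydrogen on a saturated ring carbon, so it is a weak guide to a swap of the whole group. Within the data shown here, compound 2 differs from compound 3 in more than one place and gives no clean step.

With so little evidence, no change beyond the scatter is expected, and the expected step is a 1.4-fold lower number from compound 3 to compound 4 (0.14 log units; within the scatter). Compound 4 is estimated at 8000 nM, with an expected range from 3000 nM to 20000 nM.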

Compound 4, concentration for 50% growth inhibition: 6300 nM
Compound 4: the middle estimate sits 1.3-fold (0.10 log units) above what was measured; measured number inside the range.
By their numbers in this assay, from the lowest: compounds 2, 4, 3 and 1 (each within the scatter of the next, the first and the last beyond it).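

In this assay, replacing the whole group on the carbonyl carbon gives a 1.7-fold lower number from compound 3 to compound 4 (0.24 log units; within the scatter), so this position tolerates a larger change than the single added methyl tested earlier, including the loss of the leaving group's double bond outside aromatic rings and its defined stereocentre, without a shift that can be told from the scatter. Within the data shown here, the same kind of swap starting from compound 1 gives a 2.5-fold lower number from compound 1 to compound 4 (0.40 log units; beyond the scatter), and this modest step is the first single-place change at this position to pass beyond the scatter, showing that the group on this carbonyl carbon can move the number in this assay, if only slightly. Nothing measured here accounts for why the number moves with this swap.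

The entering group differs from the leaving groups at several atoms at once, so the step cannot be assigned to any one part of it, such as its methyl groups. The compounds shown also leave open how this position would respond to something other than a six-membered non-aromatic ring with 2 hetero atoms, such as an open-chain amine or a carboxylic acid.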